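The compounds below may be only part of what the source reports. "The series", "measured", "known", "first", "only" and "open" are said of these compounds alone.

In a functional assay on A-375 cells (Homo sapiens) for activation, with a stated time of 3 days; a higher number here means that more compound is needed for the effect, a lower number that less compound is needed:
- Compound 1 `O=C(Nc1ccc(-c2cscn2)cc1)C1CCN(Cc2ccc(F)c(F)c2)C1`: 8000 nM
- Compound 2 `O=C(Nc1ccc2scnc2c1)C1CCCN(Cc2ccc(F)c(F)c2)C1`: > 20000 nM
- Compound 3 `O=C(Nc1ccc(-c2ccccc2)cc1)C1CCCN(Cc2ccc(F)c(F)c2)C1`: 5000 nM

Compound 3 gives 5000 nM and compound 1 gives 8000 nM. These two values lie within the usual scatter of each other, so the data do not separate them. Compound 2 gives > 20000 nM, which is a limit of the assay and not a number.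

The next molecule is compound 4 `O=C(Nc1ccc(-c2c[nH]cn2)cc1)C1CCCN(Cc2ccc(F)c(F)c2)C1`, which starts from compound 3 and changes a single group: 1H-imidazol-4-yl in place of phenyl on an aromatic carbon. In words, 1H-imidazol-4-yl takes the place of phenyl on an aromatic carbon, para to a large group.

Going by the values given here, no two measured compounds differ in only one place, so no measured step shows what a swap of this kind does in this assay. The expectation is therefore cautious: a modest move towards a higher number, possibly no larger than the scatter, starting from compound 3 at 5000 nM. The expected size of the change is a 2.0-fold higher number from compound 3 to compound 4 (0.30 log units; within the scatter). Compound 4 is estimated at 10000 nM, with an expected range of 3500 nM to 20000 nM. A reading at the limit of > 20000 nM in this assay, at which 1 of the 3 values shown sits, would also come as no surprise.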

Compound 4, half-maximal effective concentration: 16000 nM
For compound 4 the middle estimate is 1.6-fold (0.20 log units) below the measured one; low and high end bracket the measured number.
By their numbers in this assay, from the lowest: compounds 3, 1 and 4 (each within the scatter of the next, the first and the last beyond it). At a limit, above all of these: compound 2.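

In this assay, the swap of phenyl for 1H-imidazol-4-yl gives a 3.2-fold higher number from compound 3 to compound 4 (0.51 log units; beyond the scatter), so this place on the six-membered aromatic ring of carbon only, para to a large group, does respond to what is put there. The change is modest and more compound is needed for the effect, yet a real number can still be read: compound 4 gives 16000 nM, so this position accepts a five-membered aromatic ring with 2 hetero atoms, carrying 1 hydrogen-bond donor and 1 hydrogen-bond acceptor, without the read-out being lost. The two rings differ in size, in their nitrogen atoms and in their hydrogen-bond counts, and nothing measured here says which of these differences matters.

A pyridine ring, which keeps six ring atoms but brings in a nitrogen, or a small group such as methoxy or an amine at the same place, would help to separate these differences. Going by these compounds, compound 1 and compound 2 each differ from compound 3 in more than one place, so their steps cannot be read, and the effect of the other parts of the molecule stays open.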